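Swapping an amide direction on a pyrazole-based EP1 ligand

The source may hold more compounds than are shown below. What is called first, only, known or untested is meant among the compounds shown, and "the series" means these compounds.

Compound 1 `Cc1cc(C(=O)Nc2cccc(F)c2)nn1Cc1cc(Cl)ccc1OCc1ccccc1` was tested in an assay on CHO-K1 cells for displacement of a labelled ligand from prostaglandin E2 receptor EP1 subtype (Homo sapiens) (on this read-out higher numbers stand for weaker inhibition and lower numbers for stronger inhibition), where compound 1 gives 200 nM. A second compound, compound 2 `Cc1cc(C(=O)NN2CCCCC2)nn1Cc1cc(Cl)ccc1OCC(C)C`, was run alongside it; in this assay compound 2 gives 200 nM. The two values are level with each other at the digits shown, so nothing separates compound 1 from compound 2 within the usual scatter. Compound 3 `Cc1cc(NC(=O)CC(C)(C)C)nn1Cc1cc(Cl)ccc1OCc1ccccc1` has not yet been measured. It differs from compound 1 in one place: (neopentylcarbonyl)amino in place of (3-fluorophenyl)carbamoyl on an aromatic carbon. Among the compounds with values here, no measured pair in this set shows a change of this kind, so the size of the step can only be guessed. The expectation is a step from compound 1 to compound 3 of a 3.0-fold higher number from compound 1 to compound 3 (0.48 log units; beyond the scatter) in this assay, toward weaker inhibition, somewhat beyond the scatter. Compound 3 is accordingly estimated at 600 nM, with a plausible range from 120 nM to 3000 nM.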

Compound 3, half-maximal inhibitory concentration: 10 nM
Compound 3: the middle estimate sits 60-fold (1.78 log units) above what was measured, outside the stated range (below it).
By their numbers in this assay, from the lowest: compound 3; then compounds 1 and 2 (each within the scatter of the next).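

In this assay, putting (neopentylcarbonyl)amino in place of (3-fluorophenyl)carbamoyl on this aromatic carbon gives a 20-fold lower number from compound 1 to compound 3 (1.30 log units; beyond the scatter) and so shows that the read-out is highly sensitive to the group at this position of the shared core. The entering group has no ring, so the six-membered aromatic ring of the leaving group is not required for a low number in this series, while the counts of hydrogen-bond donors and acceptors stay the same. Nothing given here explains the size of this step.

The change reverses the amide and replaces the group at its end in one move, so the contribution of each remains unresolved. A neopentylcarbamoyl group or a 3-fluorobenzoylamino group at this position would separate the two, and a plain amine would test whether the amide is needed at all.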